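Furan to thiophene exchange on two related cores

The compounds below may be only part of what the source reports. "The series", "measured", "known", "first", "only" and "open" are said of these compounds alone.

Measured so far:
- compound 1, `COC(=O)C1=C(C)NC(=O)NC1c1ccoc1`, in an assay on membranes from CHO cells for displacement of a labelled ligand from adenosine receptor A1 (Homo sapiens), read by scintillation counting, with a stated time of 60 min, tested at 1 uM; a higher number here means more inhibition at the concentration tested (going by the name of the read-out), a lower number less inhibition: 8%
- compound 2, `COC(=O)C1=C(C)NC(=O)NC1c1cccs1`, in this assay: 6%
- compound 3, `COC(=O)C1=C(C)NC(=S)NC1c1ccoc1`, in this assay: 25%

Compound 1 and compound 2 share a core and differ in one place: thiophen-2-yl in place of furan-3-yl on a saturated ring carbon. In this assay this gave a number 2 percentage points lower from compound 1 to compound 2 (within the scatter), so the exchange left the read-out essentially where it was.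

Compound 3 carries a different core; the difference between the core of compound 1 and the core of compound 3 is not broken down here. In this assay compound 3 gives the highest of the three numbers, and its gap to compound 1 and to compound 2 lies beyond the scatter.

Compound 4, `COC(=O)C1=C(C)NC(=S)NC1c1cccs1`, is not yet measured. It differs from compound 3 in one place: thiophen-2-yl in place of furan-3-yl on a saturated ring carbon. The surroundings of the place are the same word for word as in the change from compound 1 to compound 2, so this is the same change applied on the core of compound 3, and it occurs twice among the four compounds.

For compound 4 the step is expected to be small, a number 2 percentage points lower from compound 3 to compound 4 (within the scatter), because a number 2 percentage points lower from compound 1 to compound 2 (within the scatter) showed no movement beyond the scatter. Compound 4 is therefore estimated to give 23% in this assay, with the plausible range running from 10% to 36%. This rests on a single earlier pair and on one other core, so it should be taken as a loose expectation.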

Compound 4, a percentage reported as inhibition, at one concentration (the size of the read-out at that concentration, not a potency): 1%
Beside the measured number, compound 4's estimate is 22 percentage points above it; the whole stated range lies above it.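

In this assay, thiophen-2-yl in place of furan-3-yl gave a number 24 percentage points lower from compound 3 to compound 4 (beyond the scatter), whereas the same exchange on the core of compound 1 gave a number 2 percentage points lower from compound 1 to compound 2 (within the scatter), so the step seen on one core did not carry over to the other: the same change on two cores in this assay, a number 2 percentage points lower (within the scatter) from compound 1 to compound 2 and a number 24 percentage points lower (beyond the scatter) from compound 3 to compound 4, 22 percentage points apart, beyond the scatter of two such steps

For this series, the step from the furan-3-yl compound to the thiophen-2-yl compound therefore cannot be read across from one of these two cores to the other, even though the surroundings of the place are the same word for word. For the compounds shown here, the comparison rests on only two pairs, each read at a single concentration as a percentage and not as a potency, so it does not show why the two steps differ, how the exchange would behave on any further core, or how large the difference would be in terms of potency.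

The compounds shown leave open whether the dependence on the core extends to other groups on the saturated ring carbon, such as phenyl or a pyridine ring. They also leave open what happens when the methoxycarbonyl group gives way to a carboxylic acid or an amide, or the methyl group to a longer chain.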